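Swapping the Amine Substituent for an Ethylpiperazine

A few compounds are considered here, and "the series" means these few. Any claim that something is new, unique, unknown or untested is made for them only; others in the source may bear on it.

Three compounds share one core and differ only in the group on the amine nitrogen. Compound 1 `COc1cc(Oc2cccc(Nc3ccccc3)c2)cc(OC)c1CNCCNC(C)=O` gives 5090 nM in a functional assay on HCT-15 cells (Homo sapiens) for inhibition, read by MTT assay, with a stated time of 72 h; on this read-out higher numbers stand for weaker inhibition and lower numbers for stronger inhibition. Compound 2 `COc1cc(Oc2cccc(Nc3ccccc3)c2)cc(OC)c1CN[C@H](C)c1ccccc1` gives 7550 nM in this assay, and compound 3 `COc1cc(Oc2cccc(Nc3ccccc3)c2)cc(OC)c1CNCc1ccc(Cl)cc1` gives 4850 nM. Compound 3 has the lowest number of the three, yet every step between them stays within the scatter: a 1.5-fold higher number from compound 1 to compound 2 (0.17 log units; within the scatter), a 1.0-fold lower number from compound 1 to compound 3 (0.02 log units; within the scatter) and a 1.6-fold lower number from compound 2 to compound 3 (0.19 log units; within the scatter). Compound 4 `CCN1CCN(Cc2c(OC)cc(Oc3cccc(Nc4ccccc4)c3)cc2OC)CC1` carries 4-ethylpiperazin-1-yl in place of (4-chlorobenzyl)amino on a saturated chain carbon bound to an aromatic carbon. The three measured steps all bear on this change: each likewise replaces the group on that nitrogen, and none moved the number beyond the scatter. The expectation is therefore that compound 4 shows a 1.0-fold higher number from compound 3 to compound 4 (0.01 log units; within the scatter), no step beyond the scatter. Compound 4 is estimated at 5000 nM, between 2000 nM and 12500 nM.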

Compound 4, half-maximal inhibitory concentration: 5090 nM
Beside the measured number, compound 4's estimate is 1.0-fold (0.01 log units) below it; the measured number falls inside the stated range.
By their numbers in this assay, from the lowest: compounds 3, 1, 4 and 2 (each within the scatter of the next).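

In this assay, 4-ethylpiperazin-1-yl brings a non-aromatic ring and no hydrogen-bond donor to this saturated chain carbon, yet the number holds: a 1.0-fold higher number from compound 3 to compound 4 (0.02 log units; within the scatter), a 1.5-fold lower number from compound 2 to compound 4 (0.17 log units; within the scatter) and no change at the digits printed from compound 1 to compound 4 (within the scatter). Among these four compounds, then, neither the hydrogen-bond donor on the amine nitrogen nor the aromatic ring of (4-chlorobenzyl)amino is needed to keep the number in this range. No measurement here explains why the number stays so flat. From the compounds shown here alone, whether any group at this place can move the number beyond the scatter remains open, for example a carboxylic acid or a morpholine ring.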